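This account rests on a few compounds, and the source may have more. Where it says the series, first, only, none or still open, it means among the compounds named here.

Compound 2, `NC(=O)NC[C@@H]1CCCc2cc(S(=O)(=O)c3cccc(F)c3)ccc21`, gives 0.2 nM in an assay on isolated protein for displacement of a labelled ligand from 5-hydroxytryptamine receptor 6 (Homo sapiens); a higher number here means a weaker inhibitor, a lower number a stronger inhibitor. Compound 3, `CS(=O)(=O)NC[C@@H]1CCCc2cc(S(=O)(=O)c3cccc(F)c3)ccc21`, gives 0.2 nM, and no change at the digits printed from compound 2 to compound 3 (within the scatter). Compound 1, `COCCNC[C@@H]1CCCc2cc(S(=O)(=O)c3cccc(F)c3)ccc21`, gives 0.251 nM; a 1.3-fold lower number from compound 1 to compound 2 (0.10 log units; within the scatter) and a 1.3-fold lower number from compound 1 to compound 3 (0.10 log units; within the scatter). Compound 2 therefore stands level with compound 3 at the digits shown, with compound 1 within the scatter of both.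

Compound 4, `NC(=O)NC[C@@H]1CCCc2cc(S(=O)(=O)c3cccc(F)c3)cc(F)c21`, differs from compound 2 by fluoro in place of hydrogen on an aromatic carbon. Within the data shown here, all three measured steps concern only the substituent on the amine nitrogen; none of them alters the aromatic ring, so no measured step bears directly on this change, and those that exist all lie within the scatter. Compound 4 is therefore expected to show no change beyond the scatter in this assay, estimated at 0.2 nM within 0.07 nM to 0.6 nM, a step of no change at the digits printed from compound 2 to compound 4 (within the scatter).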

Compound 4, inhibition constant: 0.2 nM
Beside the measured number, compound 4's estimate shows no gap at the digits printed; the range from low to high includes it.
By their numbers in this assay, from the lowest: compounds 2, 3, 4 and 1 (each within the scatter of the next).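

Among these compounds, the earlier compounds varied only the substituent on the amine nitrogen, whereas compound 4 gives a first reading on the aromatic ring of the shared core. In this assay, fluoro in place of hydrogen on this carbon, ortho to a fused ring, leaves the number unmoved (no change at the digits printed from compound 2 to compound 4 (within the scatter)). No measurement on hand offers an explanation for this result.

Going by these compounds, it remains open whether chloro or methoxy on this carbon would read the same. Also open, on these data alone, is whether this fluoro would behave alike with methylsulfonyl or 2-methoxyethyl on the amine nitrogen.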